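Swapping methyl for nitro on a weak sulfonamide series

The source may report more compounds than this note shows. Statements on the series, on what has been measured and on what is new or still open speak of the compounds shown alone.

Compound 1 `CCOC(=O)c1oc2ccc(NS(=O)(=O)c3ccccc3C)cc2c1C` is a weak inhibitor in a functional assay on MCF7 cells (Homo sapiens) for antiproliferative activity, read by MTT assay, with a stated time of 72 h (a lower number here means a stronger inhibitor, a higher number a weaker inhibitor), where compound 1 gives 105000 nM. Its two neighbours differ from it in one place each: compound 2 `CCOC(=O)c1oc2ccc(NS(=O)(=O)c3ccc(Cl)cc3)cc2c1C` gives 81200 nM and compound 3 `CCOC(=O)c1oc2ccc(NS(=O)(=O)c3ccccc3C(F)(F)F)cc2c1C` gives 93900 nM, so a 1.3-fold lower number from compound 1 to compound 2 (0.11 log units; within the scatter) and a 1.1-fold lower number from compound 1 to compound 3 (0.05 log units; within the scatter) both leave compound 1 indistinguishable from them within the scatter. Compound 4 `CCOC(=O)c1oc2ccc(NS(=O)(=O)c3ccccc3[N+](=O)[O-])cc2c1C` carries nitro in place of methyl on an aromatic carbon. Within the data shown here, the closest precedent is the step to compound 3, which also replaced that methyl and moved nothing beyond the scatter, and the step to compound 2 was likewise flat. Compound 4 is therefore expected to show a 1.1-fold lower number from compound 1 to compound 4 (0.02 log units; within the scatter), an estimate of 100000 nM with a range from 40000 nM to 250000 nM.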

Compound 4, half-maximal inhibitory concentration: 157000 nM
Estimate against measurement, compound 4: 1.6-fold (0.20 log units) below, within the range that was stated.
By their numbers in this assay, from the lowest: compounds 2, 3, 1 and 4 (each within the scatter of the next).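

Nitro adds two hydrogen-bond acceptors on this aromatic carbon, ortho to a large group, yet in this assay the numbers stay close: a 1.5-fold higher number from compound 1 to compound 4 (0.17 log units; within the scatter), a 1.7-fold higher number from compound 3 to compound 4 (0.22 log units; within the scatter) and a 1.9-fold higher number from compound 2 to compound 4 (0.29 log units; within the scatter). This place has now carried methyl, trifluoromethyl and nitro in compound 1, compound 3 and compound 4 without a step beyond the scatter. No measurement available here bears on why these numbers stay so close. On these data alone, whether an amine or a carboxylic acid on this carbon would give a step beyond the scatter remains open.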